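The compounds below may be only part of what the source reports. "The series", "measured", "known", "first", "only" and "open" are said of these compounds alone.

In a functional assay on B16 cells (Mus musculus) for antiproliferative activity, read by MTT assay, with a stated time of 24 h (a higher number here means a weaker inhibitor, a lower number a stronger inhibitor), compound 1 `COc1cc(OC)c(-c2coc3cc(OCC=C(C)C)ccc3c2=O)cc1OC` gives 1090 nM. Compound 2 `COc1cc(OC)c(-c2coc3cc(OCc4ccc([N+](=O)[O-])cc4)ccc3c2=O)cc1OC` is reported only as a limit of the assay, > 10000 nM. Compound 3 `COc1cc(OC)c(-c2coc3cc(OCc4ccc(C#N)cc4)ccc3c2=O)cc1OC` gives 7000 nM, the higher of the two exact numbers. Compound 4 `COc1cc(OC)c(-c2coc3cc(OCc4cccc(Br)c4)ccc3c2=O)cc1OC` differs from compound 3 by 3-bromophenyl in place of 4-cyanophenyl on a saturated chain carbon bound to an oxygen on an aromatic ring: 3-bromophenyl in place of 4-cyanophenyl. Putting 4-nitrophenyl or 4-cyanophenyl in place of 2-methylprop-1-en-1-yl gave an at least 9.1-fold higher number from compound 1 to compound 2 (0.96 log units; beyond the scatter) and a 6.4-fold higher number from compound 1 to compound 3 (0.81 log units; beyond the scatter). Exchanging nitro for cyano gave an at least 1.4-fold lower number from compound 2 to compound 3 (0.15 log units; that floor lies within the scatter), whose floor lies within the scatter. Since compound 4 also keeps a substituted phenyl, a number near that of compound 3 is expected in this assay. The estimated step is a 1.4-fold lower number from compound 3 to compound 4 (0.15 log units; within the scatter), expected to stay within the scatter. For compound 4 the estimated value is 5000 nM, with an expected range of 1500 nM to 14000 nM.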

Compound 4, half-maximal inhibitory concentration: 4400 nM
Beside the measured number, compound 4's estimate is 1.1-fold (0.06 log units) above it; measured number inside the range.
By their numbers in this assay, from the lowest: compound 1; then compounds 4 and 3 (each within the scatter of the next). At a limit, above all of these: compound 2.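

With 3-bromophenyl in place of 4-cyanophenyl, the result is a 1.6-fold lower number from compound 3 to compound 4 (0.20 log units; within the scatter), so the two benzyl ethers cannot be told apart here, although they differ in both substituent and ring position. Bromine does not close the gap to the 2-methylprop-1-en-1-yl group: a 4.0-fold higher number from compound 1 to compound 4 (0.61 log units; beyond the scatter). The step of an at least 2.2-fold lower number from compound 2 to compound 4 (0.35 log units; beyond the scatter) starts from a limit of the assay for compound 2, so it gives only a floor. On these data alone, whether an amine or a carboxylic acid on this phenyl ring would behave differently remains open. So does whether a longer chain carrying no phenyl ring would match compound 1.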